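Swapping a Methoxy Group for Bromo on Compound 3

The compounds below may be only part of what the source reports. "The series", "measured", "known", "first", "only" and "open" are said of these compounds alone.

Three measured compounds share one core and differ only in a single group on a six-membered aromatic ring of carbon only. Compound 1 `S=C(N/N=C/c1cccs1)Nc1ccccc1` carries hydrogen at that place, compound 2 `S=C(N/N=C/c1cccs1)Nc1ccc(Cl)cc1` a chloro group, and compound 3 `COc1ccc(NC(=S)N/N=C/c2cccs2)cc1` a methoxy group. In a functional assay on K562 cells (Homo sapiens) for inhibition, read by sulforhodamine B assay, with a stated time of 48 h (on this read-out higher numbers stand for weaker inhibition of growth and lower numbers for stronger inhibition of growth), compound 1 gives 16700 nM, compound 2 gives 2000 nM, and compound 3 gives 1700 nM. Compound 3 has the lowest number of the three, though its gap to compound 2 is within the scatter, so these two cannot be ranked against each other.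

Compound 4 `S=C(N/N=C/c1cccs1)Nc1ccc(Br)cc1` has not yet been measured; it differs from compound 3 by bromo in place of methoxy on an aromatic carbon. Two steps show that filling this place matters: an 8.4-fold lower number from compound 1 to compound 2 (0.92 log units; beyond the scatter) and a 9.8-fold lower number from compound 1 to compound 3 (0.99 log units; beyond the scatter). The third step, a 1.2-fold lower number from compound 2 to compound 3 (0.07 log units; within the scatter), shows that chloro and methoxy there gave numbers within the scatter of each other. No bromo group at this place has been measured. On that basis the expected step is a 1.1-fold higher number from compound 3 to compound 4 (0.05 log units; within the scatter), which is expected to stay within the scatter. Compound 4 is therefore estimated at 1900 nM, with a range from 800 nM to 4500 nM.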

Compound 4, concentration for 50% growth inhibition: > 100000 nM
Compound 4: a limit, no number (the forecaster's own chance of this, stated with the estimate: 2%); middle value at least 52-fold (1.72 log units) from the limit.
By their numbers in this assay, from the lowest: compounds 3 and 2 (each within the scatter of the next); then compound 1. At a limit, above all of these: compound 4.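

In this assay compound 4 reaches a limit of the assay, not a number: the limit of > 100000 nM in this assay, at which 1 of the 4 values shown sits. Bromo gives an at least 58-fold higher number from compound 3 to compound 4 (1.76 log units; beyond the scatter) and an at least 50-fold higher number from compound 2 to compound 4 (1.69 log units; beyond the scatter) so at this place on the aromatic ring, results with chloro and methoxy do not carry over to bromo, even though chloro and bromo are both single halogen atoms. Filling this place does not by itself give a lower number either: chloro and methoxy both gave lower numbers than hydrogen, whereas bromo gives an at least 5.9-fold higher number from compound 1 to compound 4 (0.77 log units; beyond the scatter) and so goes against that pattern.

The compounds shown leave open whether fluoro, iodo, methyl or an amine at this place would behave like chloro and methoxy or like bromo. They also do not show why bromo stands so far from chloro, and the limit leaves the true size of these steps unknown.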